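A chloro step on compound 3

The compounds below may be only part of what the source reports. "The series", "measured", "known", "first", "only" and "open" are said of these compounds alone.

Results so far in a functional assay on HO8910 cells (Homo sapiens) for inhibition, read by MTT assay, with a stated time of 24 h, tested at 0.1 ug/mL (on this read-out higher numbers stand for more inhibition of growth at the one concentration tested and lower numbers for less inhibition of growth), for three compounds:
compound 1 `O=C(CCCCC(S)CCS)Nc1ccc(Cl)cc1` gives 1.04%
compound 2 `O=C(CCCCC(S)CCS)Nc1ccc(OC(F)(F)F)cc1` gives "not active" (no number reported)
compound 3 `CC(=O)SCCC(CCCCC(=O)Nc1ccccc1)SC(C)=O` gives 8.33%

Compound 3 at 8.33% lies within the scatter of compound 1 at 1.04% and cannot be told apart from it, while compound 2 gave no number at all. Compound 4 `CC(=O)SCCC(CCCCC(=O)Nc1cccc(Cl)c1)SC(C)=O` alters compound 3 in one place (chloro in place of hydrogen on an aromatic carbon): chloro in place of hydrogen on an aromatic carbon, meta to a large group. Within the data shown here, no measured pair shows this single change alone. Compound 1 also carries a chloro group and gives 1.04% in this assay, so nothing here points to a large gain. The estimated step of a number 1.3 percentage points lower from compound 3 to compound 4 (within the scatter) is expected to stay within the scatter. The expected value for compound 4 is 7% with an estimated range of 0% to 17% in this assay.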

Compound 4, percent growth inhibition at one concentration: 0.27%
Estimate against measurement, compound 4: 6.7 percentage points above, within the range that was stated.
By their numbers in this assay, from the lowest: compounds 4, 1 and 3 (each within the scatter of the next).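

In this assay, among these compounds, the step for chloro in place of hydrogen is a number 8.1 percentage points lower from compound 3 to compound 4 (within the scatter), the first reading of a single change. At this one concentration, chloro on this aromatic carbon, meta to a large group, therefore cannot be told apart from hydrogen. Nothing measured here explains the size of this step.

Going by these compounds, whether an amine or a carboxylic acid on the same aromatic carbon would give a step beyond the scatter remains open. Also open, on these data alone, is how chloro would read on another carbon of this ring.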